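This account rests on a few compounds, and the source may have more. Where it says the series, first, only, none or still open, it means among the compounds named here.

Compound 1, `Cc1ccnc(N2C(=O)CS[C@@H]2c2cccc(C(=O)NCCCCn3cccn3)c2)c1`: 21.9 nM
Compound 2, `O=C(NCCCCc1ccccc1)c1cccc(C2SCC(=O)N2c2ccccc2)c1`: 15.9 nM

In a functional assay on HOS-TE85 cells (Homo sapiens) for inhibition, read by CCK-8 assay, with a stated time of 72 h (a lower number here means a stronger inhibitor, a higher number a weaker inhibitor), compound 2 gives 15.9 nM, the lower of the two numbers, while compound 1 gives 21.9 nM; the gap between them lies within the usual scatter, so no order between the two is claimed. Compound 3, `O=C(NCCCCc1ccccc1)c1cccc(C2SCC(=O)N2c2ccc(C3CC3)cc2)c1`, has not been measured yet. It differs from compound 2 by cyclopropyl in place of hydrogen on an aromatic carbon. Among the measured compounds shown here, no step between measured compounds covers this kind of change, so the step expected for a 1.1-fold lower number from compound 2 to compound 3 (0.03 log units; within the scatter) is small, with no clear direction and not beyond the scatter. Compound 3 is estimated at 15 nM in this assay, in a range from 6 nM to 40 nM.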

Compound 3, half-maximal inhibitory concentration: 217 nM
The estimate for compound 3 lay 14-fold (1.16 log units) below the measured number, outside the stated range (above it).
By their numbers in this assay, from the lowest: compounds 2 and 1 (each within the scatter of the next); then compound 3.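

The para place on the phenyl ring is not indifferent to substitution: in this assay cyclopropyl in place of hydrogen gives a 14-fold higher number from compound 2 to compound 3 (1.14 log units; beyond the scatter) and so a clearly weaker inhibitor. Among the compounds shown here, the earlier compounds gave no reading of any change at this place, so this is the first sign that the series responds to it. No measurement shown accounts for the step.

Going by these compounds, it remains open whether the loss belongs to cyclopropyl itself or to any group at this place. A methyl group or a fluorine atom there would separate the two.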